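Thiazole acetic acids as prostaglandin D2 receptor 2 antagonists

The source may hold more compounds than are shown below. What is called first, only, known or untested is meant among the compounds shown, and "the series" means these compounds.

Measured so far:
compound 1, `O=C(O)Cc1sc(C(c2ccccc2)c2ccccc2)nc1-c1ccccc1`, 370 nM
compound 2, `O=C(O)Cc1sc(C(c2ccc(F)cc2)c2ccc(F)cc2)nc1-c1cn[nH]c1`, 220 nM

In an in vitro functional assay on HEK285-7 cells for antagonist activity at prostaglandin D2 receptor 2 (Homo sapiens), read by BRET and beta-arrestin recruitment (on this read-out higher numbers stand for weaker inhibition and lower numbers for stronger inhibition), compound 2 gives 220 nM, the lowest of the two numbers. Its nearest neighbour is compound 1, which gives 370 nM in this assay; the two values lie within the scatter of each other, so nothing can be said of order between them.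

Compound 3, `CN(C)c1cc(-c2nc(C(c3ccc(F)cc3)c3ccc(F)cc3)sc2CC(=O)O)ccn1`, is yet to be measured in this assay. Its difference from compound 2 is 2-(dimethylamino)pyridin-4-yl in place of 1H-pyrazol-4-yl on an aromatic carbon.

Among the compounds with values here, no step between measured compounds is available, so the expected step of a 1.1-fold lower number from compound 2 to compound 3 (0.04 log units; within the scatter) is small, within the scatter, with no direction set. Compound 3 is estimated at 200 nM, in the range 70 nM to 600 nM.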

Compound 3, half-maximal inhibitory concentration: > 100000 nM
Compound 3 ended at the assay's limit; the forecaster's own chance of this, stated with the estimate: 3%; middle value at least 500-fold (2.69 log units) from the limit.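

At this position, on an aromatic carbon next to the ring nitrogen, 2-(dimethylamino)pyridin-4-yl in place of 1H-pyrazol-4-yl gives a large loss in this assay, with an at least 450-fold higher number from compound 2 to compound 3 (2.65 log units; beyond the scatter). Within the data shown here, this is the first one-place step, and it shows that the group here can decide activity. The value of compound 3 is a limit of the assay and not a number: the limit of > 100000 nM in this assay, at which 1 of the 3 values shown sits.

Still open, on these data alone, is whether the loss follows the dimethylamino group or the six-membered ring itself. Plain pyridin-4-yl, without the dimethylamino group, would separate the two.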